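Ester to methyl amide: an untested turn in microsomal stability

The compounds below may be only part of what the source reports. "The series", "measured", "known", "first", "only" and "open" are said of these compounds alone.

Measured compounds:
compound 1, `COC(=O)c1cc(N)c(Nc2ccc(C#N)cc2)cc1Oc1c(C)cc(/C=C/C#N)cc1C`, 0.308 h
compound 2, `Cc1cc(/C=C/C#N)cc(C)c1Oc1cc(Nc2ccc(C#N)cc2)c(N)cc1C(=O)OCCC#N`, 0.283 h

Among the compounds with values here, in an ADME assay on microsomes from liver (Homo sapiens) for metabolic stability, read by LC-MS, using NADPH, with a stated time of 45 min, tested at 1 uM (on this read-out higher numbers stand for a longer-lived compound and lower numbers for a shorter-lived compound), compound 2 stands lowest of the two numbers, its nearest neighbour being compound 1, and the one known step, a 1.1-fold lower number from compound 1 to compound 2 (0.04 log units; within the scatter), lies within the scatter. Compound 3, `CNC(=O)c1cc(N)c(Nc2ccc(C#N)cc2)cc1Oc1c(C)cc(/C=C/C#N)cc1C`, differs from compound 2 in that (methylamino in place of 2-cyanoethoxy on a carbonyl carbon). Within the data shown here, no measured step concerns such a change at the carbonyl carbon, so the data give no direction; the only measured step, being within the scatter, suggests nothing beyond it. For compound 3 the estimated step is a 1.2-fold higher number from compound 2 to compound 3 (0.09 log units; within the scatter). Compound 3 is therefore expected to give about 0.35 h, within a range from 0.15 h to 0.9 h.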

Compound 3, half-life in the liver assay: 1.87 h
Estimate against measurement, compound 3: 5.3-fold (0.73 log units) below; measured number above the stated range.
By their numbers in the liver assay, from the lowest: compounds 2 and 1 (each within the scatter of the next); then compound 3.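

In the liver assay, exchanging one ester for another at this carbonyl carbon stayed within the scatter, whereas methylamino on the same carbon moves the number beyond it from either ester: a 6.6-fold higher number from compound 2 to compound 3 (0.82 log units; beyond the scatter) and a 6.1-fold higher number from compound 1 to compound 3 (0.78 log units; beyond the scatter). Among these compounds, then, the read-out responds to the change from ester to amide, not to the ester chain. In a physicochemical assay for solubility, read by HPLC, in phosphate buffer, with a stated time of 4 h, at pH 7.4 (a higher number here means a more soluble compound, a lower number a less soluble compound), compound 2 gives 0.36 ug/mL and compound 3 gives 8.28 ug/mL. In the physicochemical assay the same exchange from compound 2 also raises the number: the measured solubility of compound 2, 0.36 ug/mL, and of compound 3, 8.28 ug/mL, a 23-fold higher number (1.36 log units; beyond the scatter)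

On these data alone, what a plain amino or dimethylamino group on this carbonyl carbon would give stays open, and with it whether the amide hydrogen is needed for the longer half-life.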